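Swapping the sulfonamide for a methylated sulfonyl amide

A few compounds are considered here, and "the series" means these few. Any claim that something is new, unique, unknown or untested is made for them only; others in the source may bear on it.

Measured compounds:
- compound 1 `CCS(=O)(=O)Nc1ccc(C/N=C(\S)NCc2ccc(C(C)(C)C)cc2)cc1` gives 1300 nM in a functional assay for antagonist activity at Vanilloid receptor (Rattus norvegicus); on this read-out higher numbers stand for weaker inhibition and lower numbers for stronger inhibition
- compound 2 `CCCCS(=O)(=O)Nc1ccc(C/N=C(\S)NCc2ccc(C(C)(C)C)cc2)cc1` gives 4100 nM in this assay
- compound 3 `CNS(=O)(=O)Nc1ccc(C/N=C(\S)NCc2ccc(C(C)(C)C)cc2)cc1` gives 2500 nM in this assay

Compound 3 stands second highest of the three numbers in this assay; its nearest neighbour is compound 2, with a 1.6-fold lower number from compound 2 to compound 3 (0.21 log units; within the scatter), and its furthest is compound 1, with a 1.9-fold higher number from compound 1 to compound 3 (0.28 log units; within the scatter), so compound 3 is not separated from either within the scatter. Compound 4 `CN(c1ccc(C/N=C(\S)NCc2ccc(C(C)(C)C)cc2)cc1)S(C)(=O)=O` differs from compound 3 by methyl(methylsulfonyl)amino in place of (methylsulfamoyl)amino on an aromatic carbon. The measured steps all vary the group on the sulfonyl sulfur: a 3.2-fold higher number from compound 1 to compound 2 (0.50 log units; beyond the scatter) was modest and beyond the scatter, while a 1.9-fold higher number from compound 1 to compound 3 (0.28 log units; within the scatter) and a 1.6-fold lower number from compound 2 to compound 3 (0.21 log units; within the scatter) stayed within it. None of them removes the hydrogen-bond donors as the change to compound 4 does, so the bearing of these steps is indirect. Compound 4 is therefore expected to give 5000 nM in this assay, within a range of 1500 nM to 18000 nM, an estimated step of a 2.0-fold higher number from compound 3 to compound 4 (0.30 log units; within the scatter) towards a weaker number.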

Compound 4, half-maximal inhibitory concentration: 2500 nM
For compound 4 the middle estimate is 2.0-fold (0.30 log units) above the measured one; the range from low to high includes it.
By their numbers in this assay, from the lowest: compounds 1, 3, 4 and 2 (each within the scatter of the next, the first and the last beyond it).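

In this assay, methyl(methylsulfonyl)amino in place of (methylsulfamoyl)amino on this aromatic carbon takes the group from 2 hydrogen-bond donors to 0, yet the result is no change at the digits printed from compound 3 to compound 4 (within the scatter), so at this position the loss of both donors is not accompanied by a step beyond the scatter. Compound 4 is also not separated from the two alkylsulfonyl compounds, with a 1.6-fold lower number from compound 2 to compound 4 (0.21 log units; within the scatter) and a 1.9-fold higher number from compound 1 to compound 4 (0.28 log units; within the scatter), even though those two lie apart with a 3.2-fold higher number from compound 1 to compound 2 (0.50 log units; beyond the scatter). Nothing measured here accounts for this outcome.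

The compounds shown leave open whether a longer chain, such as ethyl or butyl, on the sulfonyl-bearing nitrogen would be tolerated in the same way. They also do not show how a carboxylic acid or a primary amine would behave on this aromatic carbon.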